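N-Methylation of the Secondary Amine in the Indole Series

The source may hold more compounds than are shown below. What is called first, only, known or untested is meant among the compounds shown, and "the series" means these compounds.

Among the measured compounds shown here, in an assay on CHO cells for displacement of a labelled ligand from 5-hydroxytryptamine receptor 1B (Homo sapiens) (a higher number here means a weaker inhibitor, a lower number a stronger inhibitor), compound 2 `CC(=O)Nc1ccc(CNC2CCN(CCCc3c[nH]c4ccc(-n5cnnc5)cc34)CC2)cc1` gives 45 nM, the lowest of the two numbers so far; compound 1 `O[C@@H]1Cc2ccccc2[C@H]1NC1CCN(CCCc2c[nH]c3ccc(-n4cnnc4)cc23)CC1` gives 210 nM, and the step of a 4.7-fold lower number from compound 1 to compound 2 (0.67 log units; beyond the scatter) lies beyond the scatter. Compound 3 `CC(=O)Nc1ccc(CN(C)C2CCN(CCCc3c[nH]c4ccc(-n5cnnc5)cc34)CC2)cc1` carries methyl in place of hydrogen on an amine nitrogen. For the measured compounds named here, no measured step concerns a methyl on that amine nitrogen: the single step from compound 1 to compound 2 exchanges the whole group on it. With nothing directly comparable, the expected step is small, within the scatter, either way: a 1.3-fold higher number from compound 2 to compound 3 (0.12 log units; within the scatter). Compound 3 is estimated at 60 nM, range 20 nM to 180 nM.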

Compound 3, half-maximal inhibitory concentration: 100 nM
Estimate against measurement, compound 3: 1.7-fold (0.22 log units) below; the range from low to high includes it.
By their numbers in this assay, from the lowest: compound 2; then compound 3; then compound 1.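

In this assay, methyl in place of hydrogen on the amine nitrogen gives a 2.2-fold higher number from compound 2 to compound 3 (0.35 log units; beyond the scatter), a modest rise in the number from a single added carbon. The earlier step exchanged the whole group on this nitrogen, whereas this one keeps the 4-acetamidobenzyl group and shows that the substituent count on the nitrogen alone shifts the number. Nothing available accounts for this shift.

Open, going by these compounds, is whether an ethyl or a longer chain on this nitrogen moves the number further, and whether methyl has a similar effect alongside the 2-hydroxy-2,3-dihydro-1H-inden-1-yl group.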